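Furan-2-yl in place of iodo on a limit-bound compound

This account rests on a few compounds, and the source may have more. Where it says the series, first, only, none or still open, it means among the compounds named here.

Compound 1 `Cc1ncnc2c1c(I)cn2[C@@H]1O[C@H](CO)[C@@H](O)[C@H]1O` gives 4720 nM in a functional assay on HCT-116 cells (Homo sapiens), read by MTT assay, with a stated time of 72 h; a higher number here means a weaker inhibitor, a lower number a stronger inhibitor. For compound 2 `CNc1ncnc2c1c(I)cn2[C@@H]1O[C@H](CO)[C@@H](O)[C@H]1O` this assay reports only a limit, > 100000 nM. For compound 3 `COc1ncnc2c1c(I)cn2[C@@H]1O[C@H](CO)[C@@H](O)[C@H]1O` this assay likewise reports only a limit, > 20000 nM. The measured steps, an at least 21-fold higher number from compound 1 to compound 2 (1.32 log units; beyond the scatter) and an at least 4.2-fold higher number from compound 1 to compound 3 (0.62 log units; beyond the scatter), both alter the group on a different aromatic carbon, and the step that the two limits leave unreadable from compound 2 to compound 3 compares two limits. Compound 4 `CNc1ncnc2c1c(-c1ccco1)cn2[C@@H]1O[C@H](CO)[C@@H](O)[C@H]1O` introduces a change of another kind: furan-2-yl in place of iodo on an aromatic carbon. Going by the values given here, no measured step covers this change, and compound 2 itself stands at a limit, so neither size nor direction can be read from the data. Compound 4 is therefore expected near 80000 nM, between 15000 nM and 300000 nM. That estimate means an expected at least 1.2-fold lower number from compound 2 to compound 4 (0.09 log units; that floor lies within the scatter).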

Compound 4, half-maximal inhibitory concentration: 230 nM
Compound 4: the middle estimate sits 350-fold (2.54 log units) above what was measured; measured number below the stated range.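

In this assay furan-2-yl in place of iodo gives an at least 430-fold lower number from compound 2 to compound 4 (2.63 log units; beyond the scatter) and so shows that the aromatic carbon two ring bonds from the ring nitrogen strongly affects the read-out. The earlier steps changed only the group on a different aromatic carbon, and compound 4 is the first compound shown with a ring at this place. This step gives only a floor for the size of the change, because compound 2 stands at a limit: the limit of > 100000 nM in this assay, at which 1 of the 4 values shown sits.

The compounds shown leave open whether a phenyl or thiophen-2-yl ring would act like furan-2-yl at this carbon. They also leave open whether furan-2-yl would have a similar effect with the methyl of compound 1 or the methoxy of compound 3.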